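A few compounds are considered here, and "the series" means these few. Any claim that something is new, unique, unknown or untested is made for them only; others in the source may bear on it.

Compound 3 `COc1ccc(-c2cn([C@@H]3C[C@H](CO)N(C)O3)nn2)cc1` gives 7180 nM in a functional assay on 8305C cells (Homo sapiens) for cytotoxicity, read by MTT assay, with a stated time of 24 h (on this read-out lower numbers stand for stronger inhibition and higher numbers for weaker inhibition), standing second highest of the three numbers and within the scatter of both neighbours. Compound 2 `CN1O[C@H](n2cc(-c3ccccc3)nn2)C[C@@H]1CO` gives 8760 nM in this assay, and compound 1 `CCCCCc1ccc(-c2cn([C@H]3C[C@H](CO)N(C)O3)nn2)cc1` gives 5960 nM. Compound 4 `CCCCCc1ccc(-c2cn([C@@H]3C[C@H](CO)N(C)O3)nn2)cc1` differs from compound 3 by pentyl in place of methoxy on an aromatic carbon, on an aromatic carbon of a six-membered aromatic ring of carbon only, para to a large group. Within the data shown here, the only step on this ring is a 1.2-fold lower number from compound 2 to compound 3 (0.09 log units; within the scatter), which changed little. No step for pentyl in place of methoxy is shown, but compound 1 carries pentyl and its number lies close to that of compound 3. The expected step is therefore small, a 1.2-fold lower number from compound 3 to compound 4 (0.06 log units; within the scatter). Compound 4 is estimated at 6200 nM, between 3000 nM and 13000 nM.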

Compound 4, half-maximal inhibitory concentration: 6240 nM
Compound 4: middle estimate off by 1.0-fold (0.00 log units), on the low side; the measured number falls inside the stated range.
By their numbers in this assay, from the lowest: compounds 1, 4, 3 and 2 (each within the scatter of the next).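

In this assay, pentyl in place of methoxy gives a 1.2-fold lower number from compound 3 to compound 4 (0.06 log units; within the scatter), and pentyl in place of hydrogen gives a 1.4-fold lower number from compound 2 to compound 4 (0.15 log units; within the scatter), so all three groups on this aromatic carbon now lie within the scatter of one another. Among these compounds, the configuration at a saturated ring carbon can also be read for the first time, through a 1.0-fold higher number from compound 1 to compound 4 (0.02 log units; within the scatter), and it too stays within the scatter. That reading rests on one point: the fact that compounds 1 and 4 differ only in the configuration as drawn. As far as these compounds go, whether an amine, a carboxylic acid or a chain longer than pentyl at this place would give a step beyond the scatter stays open. So does whether this configuration matters with methoxy or hydrogen on the ring.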